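Lengthening the Alkyl Chain on a Shared Core

A few compounds are considered here, and "the series" means these few. Any claim that something is new, unique, unknown or untested is made for them only; others in the source may bear on it.

The measured compounds:
Compound 1 `CCCCCCCCCCCCCCCCOP(=O)(O)OCCSC(=S)N1CCCCC1` gives 14700 nM in a functional assay on DU-145 cells (Homo sapiens) for inhibition, read by MTT assay, with stated times of 18 h and 4 h; a higher number here means a weaker inhibitor, a lower number a stronger inhibitor.
Compound 2 `CCCOP(=O)(O)OCCSC(=S)N1CCCC1` gives > 100000 nM in this assay, which is a limit of the assay rather than a number.
Compound 3 `CCCCCCOP(=O)(O)OCCSC(=S)N1CCCCC1` gives > 100000 nM in this assay, also a limit of the assay rather than a number.

Compound 2 therefore stands at the edge of what this assay can report, and it is not alone there: the limit of > 100000 nM in this assay, at which 2 of the 3 values shown sit. Compound 4 `CCCCCCCCOP(=O)(O)OCCSC(=S)N1CCCC1` differs from compound 2 by pentyl in place of hydrogen on a saturated chain carbon, three bonds along the chain from an oxygen on an unsaturated carbon. Going by the values given here, one measured step bears on this kind of change: an at least 6.8-fold higher number from compound 1 to compound 3 (0.83 log units; beyond the scatter), so shortening the chain made the inhibitor weaker. Going from compound 2 to compound 4 lengthens the chain instead, so a lower number is expected. Compound 3, which also sits at the limit with a chain of middling length, warns that the gain may be small and the value may again be reported only as a limit. The step expected is an at least 1.2-fold lower number from compound 2 to compound 4 (0.09 log units; that floor lies within the scatter). Compound 4 is estimated at 80000 nM, with a range from 30000 nM to 200000 nM.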

Compound 4, half-maximal inhibitory concentration: 47100 nM
Compound 4: middle estimate off by 1.7-fold (0.23 log units), on the high side; the measured number falls inside the stated range.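

On the core of compound 2, pentyl in place of hydrogen on a saturated chain carbon, three bonds along the chain from an oxygen on an unsaturated carbon, gives an at least 2.1-fold lower number from compound 2 to compound 4 (0.32 log units; beyond the scatter) in this assay. Lengthening the chain therefore lowers the number on this second core as well, which matches the opposite change on the core of compound 1, where shortening gave an at least 6.8-fold higher number from compound 1 to compound 3 (0.83 log units; beyond the scatter). The full size of the new step stays unknown, because its starting point is a limit of the assay rather than a number: the limit of > 100000 nM in this assay, at which 2 of the 4 values shown sit.

Going by these compounds, what remains open is how far the number would fall with a longer chain on the core of compound 2, or how a chain ending in an amine or a carboxylic acid would behave. The two cores also cannot yet be compared directly, as no pair shown differs in the core alone.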